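Carbamate on the ring amine of compound 1

A few compounds are considered here, and "the series" means these few. Any claim that something is new, unique, unknown or untested is made for them only; others in the source may bear on it.

Compound 1 `Cc1cc(C)c(S(=O)(=O)N[C@@H](CNC(=O)C2=NO[C@]3(CN[C@H](CNc4ncc[nH]4)C3)C2)C(=O)O)c(C)c1` gives 230 nM in a functional assay for antagonist activity at integrin alpha-5/beta-1 (Homo sapiens), read by ELISA (on this read-out lower numbers stand for stronger inhibition and higher numbers for weaker inhibition), the lowest of the three numbers in hand. Compound 2 `Cc1cccc(C)c1S(=O)(=O)[C@@H](CNC(=O)C1=NOC2(CCC(CNc3ncc[nH]3)CC2)C1)C(=O)O` gives 1800 nM in this assay, and compound 3 `Cc1cc(C)c(S(=O)(=O)[C@@H](CNC(=O)C2=NOC3(CCC(C(=O)Nc4ncc[nH]4)CC3)C2)C(=O)O)c(C)c1` gives 2700 nM; both lie beyond the scatter from compound 1, compound 2 nearer and compound 3 further away. Among the measured compounds shown here, no pair among the three differs in a single place, so no single step has been measured, and the three compounds differ from one another in several places at once.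

Compound 4 `CCCCOC(=O)N1C[C@@]2(CC(C(=O)NC[C@H](NS(=O)(=O)c3c(C)cc(C)cc3C)C(=O)O)=NO2)C[C@H]1CNc1ncc[nH]1` is not yet measured. It differs from compound 1 as follows: butoxycarbonyl in place of hydrogen on an amine nitrogen in a ring. The remainder of compound 1 is kept intact, and a butoxycarbonyl takes the place of hydrogen on an amine nitrogen in a ring. Nothing in the measured set shows what such a substitution does in this assay. The expectation for compound 4 is therefore a modest step toward weaker inhibition, a 1.7-fold higher number from compound 1 to compound 4 (0.24 log units; within the scatter), carrying a wide range. The estimate for compound 4 in this assay is 400 nM, expected to fall between 120 nM and 1500 nM.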

Compound 4, half-maximal inhibitory concentration: 14 nM
Compound 4: the middle estimate sits 29-fold (1.46 log units) above what was measured; measured number outside the range, below it.
By their numbers in this assay, from the lowest: compound 4; then compound 1; then compounds 2 and 3 (each within the scatter of the next).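

The nitrogen of the five-membered ring in compound 1 accepts a substituent in this assay and responds strongly to it: butoxycarbonyl in place of hydrogen gives a 16-fold lower number from compound 1 to compound 4 (1.22 log units; beyond the scatter) and places compound 4 lowest among the compounds shown. The hydrogen on this ring amine is therefore not needed for inhibition on this read-out, and this position, next to the ring atom that bears the ((1H-imidazol-2-yl)amino)methyl group, becomes a site where a single change moves the number well beyond the scatter. Nothing measured here accounts for the size of this step.

The compounds shown leave open whether the step depends on the whole butoxycarbonyl group or on one part of it, a question that a shorter methoxycarbonyl, a benzyloxycarbonyl, a plain butyl chain without the carbonyl, or a butanoyl amide on the same nitrogen would address. They also leave open how far the chain can grow before the number rises again, and whether a sulfonyl group on this nitrogen can stand in for the carbonyl.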